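Pyrazoline sulfonamides: aryl versus styryl at the saturated carbon

The source may hold more compounds than are shown below. What is called first, only, known or untested is meant among the compounds shown, and "the series" means these compounds.

Compound 1 `Cc1cc(O)c(C2=NN(c3ccc(S(N)(=O)=O)cc3)C(c3ccccc3Cl)C2)cc1Cl` gives 3580 nM in a functional assay on NCI-H23 cells (Homo sapiens) for antiproliferative activity, with a stated time of 48 h; a higher number here means a weaker inhibitor of growth, a lower number a stronger inhibitor of growth.
Compound 2 `Cc1cc(O)c(C2=NN(c3ccc(S(N)(=O)=O)cc3)C(/C=C/c3ccccc3)C2)cc1Cl` gives 12500 nM in this assay.

Among the compounds with values here, compound 2 stands with the higher of the two numbers; the only measured step, a 3.5-fold higher number from compound 1 to compound 2 (0.54 log units; beyond the scatter), runs toward it. Compound 3 `COc1ccc(C2CC(c3cc(Cl)c(C)cc3O)=NN2c2ccc(S(N)(=O)=O)cc2)cc1OC` changes it so: 3,4-dimethoxyphenyl in place of 2-phenylethenyl on a saturated ring carbon. This reverses the kind of change seen in that step, since an aromatic ring of carbon only again sits on the saturated ring carbon, as in compound 1. Within the data shown here, a lower number is therefore expected, of roughly that size; the two methoxy groups have no measured precedent here. Compound 3 is estimated at 5000 nM, range 2000 nM to 14000 nM, an expected step of a 2.5-fold lower number from compound 2 to compound 3 (0.40 log units; beyond the scatter).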

Compound 3, concentration for total growth inhibition: 13600 nM
Estimate against measurement, compound 3: 2.7-fold (0.43 log units) below; low and high end bracket the measured number.
By their numbers in this assay, from the lowest: compound 1; then compounds 2 and 3 (each within the scatter of the next).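

At this saturated ring carbon, an aromatic ring of carbon only does not by itself bring the lower number in this assay: 3,4-dimethoxyphenyl and 2-phenylethenyl read alike, with a 1.1-fold higher number from compound 2 to compound 3 (0.04 log units; within the scatter). Against 2-chlorophenyl, 3,4-dimethoxyphenyl gives a 3.8-fold higher number from compound 1 to compound 3 (0.58 log units; beyond the scatter), so compound 1 alone stands apart among the three. No measurement shown accounts for this.

Still open, as far as these compounds go, is whether the chlorine itself carries the difference, and how unsubstituted phenyl, 2-methoxyphenyl or cyclohexyl would read at this carbon.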